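Chlorinated carboxyphenyl swap on two related cores

This account rests on a few compounds, and the source may have more. Where it says the series, first, only, none or still open, it means among the compounds named here.

Compound 1, `Cc1c(OCCCCOc2cccc(C(=O)O)c2)ccc(C(=O)CC(C)C)c1O`, in an assay on HEK293 cells for positive allosteric modulation of metabotropic glutamate receptor 3 (Rattus norvegicus), read by thallium flux, with a stated time of 2.5 min (a lower number here means that less compound is needed, a higher number that more compound is needed for the effect), gives 1430 nM.
Compound 2, `Cc1c(OCCCCOc2ccc(C(=O)O)c(Cl)c2)ccc(C(=O)CC(C)C)c1O`, in this assay gives 2050 nM.
Compound 3, `Cc1c(OCCCCOc2cccc(C(=O)O)c2)ccc(C(=O)CC2CCCC2)c1C`, in this assay is recorded as "not determined" (no result reported).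

Compounds 1 and 2 share one core and differ at one end of the chain, where (4-carboxy-3-chlorophenyl in place of 3-carboxyphenyl on an oxygen on a saturated carbon). This change carried a 1.4-fold higher number from compound 1 to compound 2 (0.16 log units; within the scatter), so the two numbers for these compounds cannot be told apart with confidence.

Compound 3 is built on a different core, and the difference between the two cores is not broken down here. On these data alone, no single number was reported for compound 3, so its level in this assay is unknown.

Compound 4, `Cc1c(OCCCCOc2ccc(C(=O)O)c(Cl)c2)ccc(C(=O)CC2CCCC2)c1C`, has not yet been measured. It stands to compound 3 as compound 2 stands to compound 1: 4-carboxy-3-chlorophenyl in place of 3-carboxyphenyl on an oxygen on a saturated carbon. The place of the change is described in the same words for both pairs, so this is the same change made on a second core.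

Because the earlier instance of this change produced a 1.4-fold higher number from compound 1 to compound 2 (0.16 log units; within the scatter), the step from compound 3 to compound 4 is expected to be of a similar small size, within the usual scatter. With no number for compound 3, the absolute level of compound 4 can be anchored only to the range seen for compounds 1 and 2 on the other core, and the uncertainty is therefore wide. Compound 4 is estimated at 2500 nM, with a likely range from 600 nM to 10000 nM.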

Compound 4, half-maximal effective concentration: > 10000 nM
Compound 4 ended at the assay's limit; the forecaster's own chance of this, stated with the estimate: 30%; middle value at least 4.0-fold (0.60 log units) from the limit.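

In this assay compound 4 gives > 10000 nM, which is a limit of the assay and not a number. Among the compounds shown here, compound 3 carries no number, so no step between compound 3 and compound 4 can be read. The compounds shown leave open whether 4-carboxy-3-chlorophenyl in place of 3-carboxyphenyl has the same effect on the core of compound 3 as on the core of compound 1.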